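Replacing the (tert-butyl)carbonyl group of compound 2

The compounds below may be only part of what the source reports. "The series", "measured", "known", "first", "only" and "open" are said of these compounds alone.

In a functional assay on MCF7 cells (Homo sapiens), read by MTT assay, with a stated time of 48 h (a lower number here means a stronger inhibitor, a higher number a weaker inhibitor), compound 1 (`CCN(CC)CCNC(=O)c1ccc(C(CC)(CC)c2ccc(OCC(=O)C(C)(C)C)c(C)c2)n1CC`) gives 690 nM and compound 2 (`CCn1c(C(=O)NCCCN(C)C)ccc1C(CC)(CC)c1ccc(OCC(=O)C(C)(C)C)c(C)c1`) gives 340 nM. Going by the values given here, compound 2 therefore holds the lower of the only two numbers available, and compound 1 is its sole neighbour. Compound 3 (`CCn1c(C(=O)NCCCN(C)C)ccc1C(CC)(CC)c1ccc(OCC(O)C(C)(C)C)c(C)c1`) keeps the amide chain of compound 2 and differs elsewhere: 1-hydroxy-2,2-dimethylpropyl in place of (tert-butyl)carbonyl on a saturated chain carbon bound to an oxygen on an aromatic ring. In short, 1-hydroxy-2,2-dimethylpropyl stands in place of (tert-butyl)carbonyl on a saturated chain carbon bound to an oxygen on an aromatic ring.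

Among the compounds with values here, the only measured step, a 2.0-fold lower number from compound 1 to compound 2 (0.31 log units; beyond the scatter), is modest and just beyond the scatter. It lies in the amide chain, not at the place that changes here, so it gives only a rough scale for a single change in this series. Within the data shown here, no measured pair varies the (tert-butyl)carbonyl group, and the data therefore indicate no direction. The estimated step is a 1.1-fold lower number from compound 2 to compound 3 (0.05 log units; within the scatter), which is expected to stay within the scatter. Compound 3 is estimated at 300 nM, with an expected range of 110 nM to 800 nM.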

Compound 3, half-maximal inhibitory concentration: 490 nM
For compound 3 the middle estimate is 1.6-fold (0.21 log units) below the measured one; measured number inside the range.
By their numbers in this assay, from the lowest: compounds 2, 3 and 1 (each within the scatter of the next, the first and the last beyond it).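

Going by these compounds alone, compound 3 gives the first reading at this position: this assay shows a 1.4-fold higher number from compound 2 to compound 3 (0.16 log units; within the scatter) for 1-hydroxy-2,2-dimethylpropyl in place of (tert-butyl)carbonyl on a saturated chain carbon bound to an oxygen on an aromatic ring. The exchange removes the double bond outside aromatic rings and brings in a hydrogen-bond donor at an unchanged heavy-atom count, yet the step does not leave the scatter, so in this single pair the position accepts the change without a resolved shift in the number. No available measurement bears on the reason for this outcome.

On these data alone, whether a carboxylic acid, an amine or a longer chain at this same place would give a step beyond the scatter stays open, since one pair cannot define the range of groups the position accepts. Also open is whether the step seen in the amide chain between diethylamino and (dimethylamino)methyl carries over when 1-hydroxy-2,2-dimethylpropyl is present, as the compounds shown test that amide change only with (tert-butyl)carbonyl in place.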